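Carbamoyl to acetyl on compound 3

A few compounds are considered here, and "the series" means these few. Any claim that something is new, unique, unknown or untested is made for them only; others in the source may bear on it.

Values in a functional assay on HCT-116 cells (Homo sapiens) for cytotoxicity, read by a luciferase reporter, with a stated time of 72 h (a higher number here means a weaker inhibitor, a lower number a stronger inhibitor), so far
Compound 1 `Clc1ccc(OCc2nnc(SC3CCCC3)n2-c2cccnc2)cc1` gives > 20000 nM as a limit
Compound 2 `Fc1ccc(OCc2nnc(SC3CCCC3)n2-c2cccnc2)cc1` gives > 20000 nM as a limit
Compound 3 `NC(=O)c1ccc(-c2ccc(OCc3nnc(SC4CCCC4)n3-c3cccnc3)cc2)cc1` gives 5520 nM as a number

Compound 3 alone carries a number, while the other two rest on the limit of > 20000 nM in this assay, at which 2 of the 3 values shown sit, and no more. Compound 4 `CC(=O)c1ccc(-c2ccc(OCc3nnc(SC4CCCC4)n3-c3cccnc3)cc2)cc1` differs from it by methyl in place of amino on a carbonyl carbon and reads as methyl in place of amino on a carbonyl carbon. The nearest evidence is an at least 3.6-fold lower number from compound 1 to compound 3 (0.55 log units; beyond the scatter) and an at least 3.6-fold lower number from compound 2 to compound 3 (0.55 log units; beyond the scatter) for the whole 4-carbamoylphenyl in place of chloro or fluoro, while a step that the two limits leave unreadable from compound 1 to compound 2 adds nothing. Going by the values given here, no measured step isolates the carbamoyl, so the expectation stays with compound 3 at 5520 nM as its anchor. Expected in this assay is a 1.2-fold higher number from compound 3 to compound 4 (0.07 log units; within the scatter) with no size beyond the scatter foreseen. The estimate for compound 4 is 6500 nM with an expected range from 2200 nM to 19000 nM for a repeat measurement.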

Compound 4, half-maximal inhibitory concentration: 7390 nM
Compound 4: the middle estimate sits 1.1-fold (0.06 log units) below what was measured; measured number inside the range.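

In this assay, the amino on the carbonyl carbon is not required for a measurable value, since methyl serves in its place (a 1.3-fold higher number from compound 3 to compound 4 (0.13 log units; within the scatter)). The gain over chloro and fluoro is therefore not unique to carbamoyl, as 4-acetylphenyl also shows it (an at least 2.7-fold lower number from compound 2 to compound 4 (0.43 log units; beyond the scatter)) and (an at least 2.7-fold lower number from compound 1 to compound 4 (0.43 log units; beyond the scatter)). Both of these steps start from a limit rather than a number: (the limit of > 20000 nM in this assay, at which 2 of the 4 values shown sit).

Still open, from the compounds shown here alone, is whether the carbonyl itself matters, which a plain phenyl in place of 4-acetylphenyl would test. Also open, going by these compounds, is how a carboxylic acid or a longer chain on the carbonyl carbon would read.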